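A few compounds are considered here, and "the series" means these few. Any claim that something is new, unique, unknown or untested is made for them only; others in the source may bear on it.

For the measured compounds named here, in a functional assay on cells for agonist activity at melatonin receptor type 1B (Homo sapiens), read by GTPgammaS binding, with a stated time of 30 min (on this read-out lower numbers stand for smaller maximal responses and higher numbers for larger maximal responses), compound 1 `CC(=O)NCCN(C)c1cccc(OCCCCN)c1` gives 0.35, the lowest of the three numbers measured so far. Compound 2 `CC(=O)NCCN(C)c1cccc(OCCCCNC(=O)Oc2cccc(-c3ccccc3)c2)c1` gives 0.39, which lies within the usual scatter of compound 1, so the two cannot be told apart. Compound 3 `CC(=O)NCCN(C)c1cccc(OCCCCCCNC(=O)Oc2cccc(-c3cccc(C(N)=O)c3)c2)c1` gives 1.01, well beyond the scatter above compound 1. Compound 4 `CC(=O)NCCN(C)c1cccc(OCCCCOc2cccc(O)c2)c1` has not yet been measured; it differs from compound 1 in one place: 3-hydroxyphenoxy in place of amino on a saturated chain carbon, four bonds along the chain from an oxygen on an aromatic ring. Going by the values given here, no measured pair differs in a single place, so the size of this step is uncertain. A rise of moderate size, a number 0.20 higher from compound 1 to compound 4 (beyond the scatter), is expected, because compound 3 reaches 1.01 while compound 2 stays at 0.39. For compound 4 the expected value is 0.55, with a likely range from 0.3 to 0.85.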

Compound 4, intrinsic activity: the largest response reached, as a fraction of the reference agonist's: 0.18
Compound 4: middle estimate off by 0.37, on the high side; measured number outside the range, below it.
By their numbers in this assay, from the lowest: compound 4; then compounds 1 and 2 (each within the scatter of the next); then compound 3.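

In this assay, for the compounds shown here, 3-hydroxyphenoxy in place of amino gives the only single-place step read so far at this position: a number 0.17 lower from compound 1 to compound 4 (beyond the scatter). Bringing an aromatic ring and more heavy atoms to this position therefore does not by itself raise the maximal response, and here the response falls. Nothing measured here explains this fall. From the compounds shown here alone, whether plain phenoxy, a carboxylic acid or a methoxy group in this place would lower the response too remains open. So does whether 3-hydroxyphenoxy would give a step of the same size on a longer chain.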